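A few compounds are considered here, and "the series" means these few. Any claim that something is new, unique, unknown or untested is made for them only; others in the source may bear on it.

Measured so far in an ADME assay on microsomes from liver (Homo sapiens) for metabolic stability; on this read-out higher numbers stand for fast clearance and lower numbers for slow clearance:
Compound 1 `CCC(Oc1ccc(-n2cc(C(F)(F)F)cn2)cc1)c1ccc(C(=O)NCCC(=O)O)cc1` gives < 8 mL/min/kg, which is a limit of the assay.
Compound 2 `CCCC(Oc1ccc(-n2cc(C(=O)N(C)C)cn2)cc1)c1ccc(C(=O)NCCC(=O)O)cc1` gives < 13 mL/min/kg, which is also a limit of the assay.

Compound 2 therefore stands at a limit of this assay, not at a measured number, and the two values shown, both limits, give no ordering between compound 1 and compound 2; each shows slow clearance on this read-out (the limit of < 13 mL/min/kg in this assay, at which 1 of the 2 values shown sits, and (the limit of < 8 mL/min/kg in this assay, at which 1 of the 2 values shown sits)). Compound 3 `CCCC(Oc1ccc(-n2cc(C(F)(F)F)c(C)n2)cc1)c1ccc(C(=O)NCCC(=O)O)cc1` differs from compound 2 by 3-methyl-4-(trifluoromethyl)-1H-pyrazol-1-yl in place of 4-(dimethylcarbamoyl)-1H-pyrazol-1-yl on an aromatic carbon. No measured step between the shown compounds tells how such a change moves clearance. Since compound 1 also carries a trifluoromethyl on its pyrazol-1-yl and sits at the limit of < 8 mL/min/kg in this assay, at which 1 of the 2 values shown sits, compound 3 is expected to remain slow as well. The expected step that the limit leaves unreadable from compound 2 to compound 3 is within the usual scatter, and the estimate for compound 3 is 8 mL/min/kg, with a range from 4 mL/min/kg to 20 mL/min/kg, quite possibly reported only as a limit again.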

Compound 3, clearance: < 10 mL/min/kg
Compound 3 was reported as a limit (the forecaster's own chance of this, stated with the estimate: 60%); the middle value does not contradict the limit.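

In this assay, for the compounds shown here, compound 2 and compound 3 are both reported only as limits, and no step between them can be read. The compounds shown leave open how far, if at all, 3-methyl-4-(trifluoromethyl)-1H-pyrazol-1-yl in place of 4-(dimethylcarbamoyl)-1H-pyrazol-1-yl moves clearance.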